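Furan-2-yl for 4-Methylphenyl on a Nitroimidazole Thioether

This account rests on a few compounds, and the source may have more. Where it says the series, first, only, none or still open, it means among the compounds named here.

Compound 1 `Cc1ccc(-c2nnc(SCCn3c([N+](=O)[O-])cnc3C)o2)cc1` gives 12500 nM in a functional assay on SGC-7901 cells (Homo sapiens) for cytotoxicity, read by MTT assay, with a stated time of 48 h (on this read-out higher numbers stand for weaker inhibition and lower numbers for stronger inhibition), the highest of the three numbers, though compound 2 `Cc1ncc([N+](=O)[O-])n1CCSc1nnc(-c2ccc([N+](=O)[O-])cc2)o1` at 12200 nM and compound 3 `COc1cc(OC)cc(-c2nnc(SCCn3c([N+](=O)[O-])cnc3C)o2)c1` at 9600 nM both lie within the scatter of it. Within the data shown here, the only measured step, a 1.0-fold lower number from compound 1 to compound 2 (0.01 log units; within the scatter), swaps a substituent on an aromatic carbon and moves the number hardly at all. Among the measured compounds shown here, compound 4 `Cc1ncc([N+](=O)[O-])n1CCSc1nnc(-c2ccco2)o1` differs from compound 1 by furan-2-yl in place of 4-methylphenyl on an aromatic carbon, an exchange of the whole ring rather than of a substituent on it; no measured step covers such an exchange. With nothing in the data pointing to a larger effect, the expected step is a 1.0-fold lower number from compound 1 to compound 4 (0.02 log units; within the scatter), none beyond the scatter. Compound 4 is therefore estimated at 12000 nM, between 4500 nM and 32000 nM.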

Compound 4, half-maximal inhibitory concentration: 31700 nM
Compound 4: the middle estimate sits 2.6-fold (0.42 log units) below what was measured; measured number inside the range.
By their numbers in this assay, from the lowest: compounds 3, 2 and 1 (each within the scatter of the next); then compound 4.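

In this assay, the aromatic carbon next to the ring nitrogen and the ring oxygen proves sensitive to an exchange of the whole ring: furan-2-yl in place of 4-methylphenyl gives a 2.5-fold higher number from compound 1 to compound 4 (0.40 log units; beyond the scatter), a modest loss of inhibition. The substituent swap on the 4-methylphenyl ring, by contrast, gave only a 1.0-fold lower number from compound 1 to compound 2 (0.01 log units; within the scatter), so this is the first change shown to move the number at all.

The compounds shown leave open whether thiophen-2-yl or an amine on this carbon would give a number closer to that of compound 1 or that of compound 4. Nothing measured here accounts for the step, and whether it follows from the smaller ring or from its oxygen remains unsettled.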